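Replacing 3-carboxypropyl with 2-carboxyphenyl on a shared core

This account rests on a few compounds, and the source may have more. Where it says the series, first, only, none or still open, it means among the compounds named here.

Three acid-bearing compounds on a shared core have been measured in a functional assay on NCI-H441 cells (Homo sapiens) for antiproliferative activity, with a stated time of 24 h (a lower number here means a stronger inhibitor, a higher number a weaker inhibitor), so far. Compound 1 (`O=C(O)/C=C/C(=O)N1C/C(=C\c2ccccc2F)C(=O)/C(=C/c2ccccc2F)C1`) gives 29000 nM with 2-carboxyethenyl on the carbonyl carbon. Compound 2 (`O=C(O)COCC(=O)N1C/C(=C\c2ccccc2F)C(=O)/C(=C/c2ccccc2F)C1`) gives 310000 nM with (carboxymethoxy)methyl in that place. Compound 3 (`O=C(O)CCCC(=O)N1C/C(=C\c2ccccc2F)C(=O)/C(=C/c2ccccc2F)C1`) gives 60000 nM with 3-carboxypropyl and holds the middle of the three numbers.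

Compound 4 (`O=C1/C(=C/c2ccccc2F)CN(C(=O)c2ccccc2C(=O)O)C/C1=C\c1ccccc1F`) has 2-carboxyphenyl in place of 3-carboxypropyl on a carbonyl carbon whose other neighbour is an amide-type nitrogen in a ring (2-carboxyphenyl in place of 3-carboxypropyl on a carbonyl carbon). Within the data shown here, no measured compound carries an aromatic ring in this side chain, so the evidence is indirect. Changes at this same carbonyl carbon gave a modest step (a 2.1-fold higher number from compound 1 to compound 3 (0.32 log units; beyond the scatter)) and a large one (an 11-fold higher number from compound 1 to compound 2 (1.03 log units; beyond the scatter)), while the remaining pair also differed modestly (a 5.2-fold lower number from compound 2 to compound 3 (0.71 log units; beyond the scatter)). The side chain of compound 1 comes closest to the new group, since both hold unsaturated carbons, and compound 1 has the lowest number at 29000 nM in this series. A modest step to a lower number is therefore expected. By this estimate the expected change is a 2.1-fold lower number from compound 3 to compound 4 (0.33 log units; beyond the scatter) in this series. The estimated value for compound 4 is 28000 nM with an expected range of 9000 nM to 90000 nM in this assay here.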

Compound 4, half-maximal inhibitory concentration: 56000 nM
Estimate against measurement, compound 4: 2.0-fold (0.30 log units) below, within the range that was stated.
By their numbers in this assay, from the lowest: compounds 1, 4 and 3 (each within the scatter of the next, the first and the last beyond it); then compound 2.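

In this assay, the aromatic ring of 2-carboxyphenyl on this carbonyl carbon gives a number that cannot be told apart from that of the open chain 3-carboxypropyl (a 1.1-fold lower number from compound 3 to compound 4 (0.03 log units; within the scatter)), even though the group entering has 9 heavy atoms against 6 for the group leaving. Compound 4 also cannot be told apart from the unsaturated side-chain compound (a 1.9-fold higher number from compound 1 to compound 4 (0.29 log units; within the scatter)), so it falls within the scatter of both compound 1 and compound 3, although those two lie beyond the scatter of each other. The side chain of compound 2 now stands apart from all three others, and the new comparison adds to this (a 5.5-fold lower number from compound 2 to compound 4 (0.74 log units; beyond the scatter)), so at this place an aromatic ring carrying the acid is accommodated in this series, while (carboxymethoxy)methyl alone gives a clearly higher number.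

From the compounds shown here alone, whether the carboxylic acid is needed at all stays open, as does what a plain phenyl, an amine or a 3-carboxyphenyl group would give at this carbonyl carbon. Nothing in the material shown offers an explanation for these numbers.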